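This account rests on a few compounds, and the source may have more. Where it says the series, first, only, none or still open, it means among the compounds named here.

Compound 1 `COc1cc(/C=C/C(=O)C2=C(/C=C/c3ccc(O)c(OC)c3)NC(=O)NC2c2ccc(N(C)C)cc2)ccc1O`: 89.2%
Compound 2 `COc1cc(/C=C/C(=O)C2=C(/C=C/c3ccc(O)c(OC)c3)NC(=S)NC2c2ccccc2)ccc1O`: 50.4%
Compound 3 `COc1cc(/C=C/C(=O)C2=C(/C=C/c3ccc(O)c(OC)c3)NC(=S)NC2c2ccc(C)cc2)ccc1O`: 41%

Three compounds of the series have numbers in a functional assay, with a stated time of 20 min, tested at 50 uM; a higher number here means a stronger effect of the compound at the concentration tested, a lower number a weaker effect. Compound 3 gives the lowest of the three. Its nearest neighbour is compound 2 with 50.4%, within the scatter of compound 3, so the two cannot be ordered. Compound 1, at 89.2%, lies beyond the scatter from compound 3; compound 1 differs from the other two in more than one place, so nothing beyond the two values themselves is drawn from it.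

Compound 4 `COc1cc(/C=C/C(=O)C2=C(/C=C/c3ccc(O)c(OC)c3)NC(=S)NC2c2ccccc2O)ccc1O` is the next member. It differs from compound 3 as follows: 2-hydroxyphenyl in place of 4-methylphenyl on a saturated ring carbon. Within the data shown here, the only measured step that alters the group on the saturated ring carbon is a number 9.4 percentage points lower from compound 2 to compound 3 (within the scatter), a change that stayed within the scatter. Among the measured compounds shown here, no measured step introduces a hydroxy group, so the entering 2-hydroxyphenyl has no precedent in the numbers; the one step that is known at this position was small.

On that basis compound 4 is expected to give about 45%, with a range of 22% to 70%. The step this implies, a number 4 percentage points higher from compound 3 to compound 4 (within the scatter), is expected to stay within the scatter, with the caveat that the range is set wide.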

Compound 4, a percentage reported as activity, at one concentration (the size of the read-out at that concentration, not a potency): 88.5%
Estimate against measurement, compound 4: 43.5 percentage points below, and the stated range ends below it.
By their numbers in this assay, from the lowest: compounds 3 and 2 (each within the scatter of the next); then compounds 4 and 1 (each within the scatter of the next).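

In this assay, among these compounds, the group on the saturated ring carbon proves able to move the read-out well beyond the scatter: a number 47.5 percentage points higher from compound 3 to compound 4 (beyond the scatter) on replacing 4-methylphenyl with 2-hydroxyphenyl, whereas the only earlier step at this position, a number 9.4 percentage points lower from compound 2 to compound 3 (within the scatter), stayed within it. The cleanest comparison is a number 38.1 percentage points higher from compound 2 to compound 4 (beyond the scatter), where hydroxy replaces hydrogen on an aromatic carbon and nothing else changes, so the shift in this pair belongs to that single hydroxy group, while the methyl of compound 3 shows no comparable shift. No measurement on hand accounts for the size of this step.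

As far as these compounds go, whether the effect needs a free hydroxy at all remains open, since a methoxy group or an amine in that place on the aryl ring would separate the hydroxy from other oxygen- or nitrogen-bearing groups, and a fluorine would test a small group that carries no hydrogen. Compound 1 differs from the others in more than one place, so the separate contributions of its carbonyl and its 4-(dimethylamino)phenyl group stay unresolved, and a single-place pair for either is still needed.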